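This account rests on a few compounds, and the source may have more. Where it says the series, first, only, none or still open, it means among the compounds named here.

Working notes on a small set of benzyl-protected sugar-derived compounds tested in a functional assay on HL-60 cells (Homo sapiens) for antiproliferative activity, read by MTT assay; on this read-out lower numbers stand for stronger inhibition and higher numbers for weaker inhibition.

Compound 1 `CCC[C@@H]1O[C@H](COCc2ccccc2)[C@@H](OCc2ccccc2)[C@H](OCc2ccccc2)[C@@H]1O` is reported in this assay as "not active" (no number reported), with no concentration given. Compound 2 `C=CC[C@@H]1O[C@H](COCc2ccccc2)[C@@H](OCc2ccccc2)[C@H](OCc2ccccc2)[C@@H]1O` carries an allyl chain where compound 1 carries propyl. In this assay compound 2 is likewise reported as "not active" (no number reported), again without a number. Among the compounds with values here, compound 3 `O[C@@H]1[C@@H](O)[C@H](Cc2ccccc2)O[C@H](COCc2ccccc2)[C@H]1OCc1ccccc1`, with a benzyl group on the ring carbon and one benzyl ether fewer, is the only member with a measured concentration: in this assay compound 3 gives 26600 nM. Compound 1 therefore stands among the entries that gave no number at all, and nothing in the shown data places it ahead of or behind compound 2.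

Compound 4 `CCC[C@H]1O[C@H](COCc2ccccc2)[C@H](OCc2ccccc2)[C@H](OCc2ccccc2)[C@H]1O` is the next member to be measured. Its relation to compound 1 is the two compounds have the same atoms and bonds and differ only in configuration as drawn: 3 of 5 stereo elements differ; a stereocentre at a saturated ring carbon is drawn S in compound 1 and R in compound 4; a stereocentre at a saturated ring carbon is drawn R in compound 1 and S in compound 4; a stereocentre at a saturated ring carbon is drawn R in compound 1 and S in compound 4.

Within the data shown here, no step between measured compounds is available in this set, so no direction can be read from it. Given that compound 1 returned "not active" (no number reported) and the sole number in the series, from compound 3, is 26600 nM, compound 4 is expected to be weak. The estimate for compound 4 in this assay is 40000 nM, within a range of 15000 nM to 150000 nM.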

Compound 4, half-maximal inhibitory concentration: "not active" (no number reported)
Compound 4: no number reported; there is nothing to compare the estimate with.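

With compound 1 and compound 4 both reported without a number in this assay, no new step can be read between them. Within the data shown here, whether configuration affects activity stays open, since neither compound gives a concentration and the one measured value belongs to compound 3, whose structure differs in more than one place.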